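Hydrogen in place of nitro: a small step expected

This account rests on a few compounds, and the source may have more. Where it says the series, first, only, none or still open, it means among the compounds named here.

In an ADME assay on BHK cells (Mesocricetus auratus) for cytotoxicity, read by MTT assay, with a stated time of 96 h (a higher number here means that more compound is tolerated, a lower number that less compound is tolerated), compound 1 `O=[N+]([O-])c1ccc(NC(=S)Nc2cccc(C(F)(F)F)c2)cc1` gives 9500 nM as its measured value. Compound 2 `Cc1ccc(NC(=S)Nc2cccc(C(F)(F)F)c2)cc1Cl` gives 10000 nM in this assay as well. Among the compounds with values here, these two numbers lie within the usual scatter of each other, so compound 1 cannot be told apart from the only other measured compound.

The next compound, compound 3 `FC(F)(F)c1cccc(NC(=S)Nc2ccccc2)c1`, differs from compound 1 in one place, with hydrogen in place of nitro on an aromatic carbon and this carbon is para to a large group. Within the data shown here, no measured pair shows this change on its own, so the evidence is thin. Compound 2 has no nitro and gives 10000 nM all the same, which is why no step beyond the scatter is expected.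

The estimated step is a 1.3-fold higher number from compound 1 to compound 3 (0.10 log units; within the scatter) in the direction of more compound tolerated, a size that stays within the scatter. For compound 3 the estimated value is 12000 nM with an expected range from 5000 nM to 30000 nM in this assay once it is measured.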

Compound 3, half-maximal cytotoxic concentration: 41000 nM
Beside the measured number, compound 3's estimate is 3.4-fold (0.53 log units) below it, and the stated range ends below it.
By their numbers in this assay, from the lowest: compounds 1 and 2 (each within the scatter of the next); then compound 3.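

In this assay, replacing nitro with hydrogen on the aromatic carbon para to a large group gives a 4.3-fold higher number from compound 1 to compound 3 (0.64 log units; beyond the scatter), a step beyond the scatter. Compounds 1 and 2 could not show this, as they differ in more than one place and their numbers lie within the scatter of each other. Within the data shown here, the pair of compound 1 and compound 3 is the first in which this change stands alone, and it shows that what sits at this position can shift how much compound the cells tolerate, with hydrogen here giving the higher number. No accompanying measurement accounts for the size or direction of this step.

A single pair cannot tell whether nitro is unusual at this position or whether any group there would give a lower number than hydrogen. An amine, a methoxy group or a carboxylic acid at the same carbon on the core of compound 3 would each differ from it in one place, and so could begin to separate these two readings.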